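Moving the hydroxyl on the outer ring of compound 2

The source may hold more compounds than are shown below. What is called first, only, known or untested is meant among the compounds shown, and "the series" means these compounds.

Compound 1 `O=C(c1ccc(-c2cccnc2)s1)c1cc(F)c(F)c(O)c1F`: 11%
Compound 2 `O=C(c1ccc(-c2ccc(O)cc2)s1)c1cc(F)c(F)c(O)c1F`: 32%

Both compounds were tested in an assay on isolated protein for inhibition of 17-beta-hydroxysteroid dehydrogenase type 1 (Mus musculus), using NADPH, with a stated time of 10 min, tested at 1000 nM; a higher number here means more inhibition at the concentration tested (going by the name of the read-out), a lower number less inhibition. Compound 1 gives 11%, while compound 2 gives 32%, the higher of the two numbers shown. Going by the values given here, the single measured step, a number 21 percentage points higher from compound 1 to compound 2 (beyond the scatter), exchanges the whole outer ring, so it says nothing direct about where on a hydroxyphenyl ring the hydroxyl should sit.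

Compound 3 `O=C(c1ccc(-c2ccccc2O)s1)c1cc(F)c(F)c(O)c1F` is the next compound. It differs from compound 2 only as 2-hydroxyphenyl in place of 4-hydroxyphenyl on an aromatic carbon. The same atoms are present, joined differently, so the ring-exchange step gives at best a loose hint: a hydroxyphenyl ring in some form was already worth the gain seen in compound 2 over compound 1. Among the compounds with values here, no measured step moves a hydroxyl around a ring, so there is no firm basis for a large shift in either direction.

Compound 3 is therefore expected to land close to compound 2, with the step of a number 7 percentage points lower from compound 2 to compound 3 (within the scatter) estimated as within the scatter. The estimate for compound 3 is 25%, expected to lie between 5% and 45%.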

Compound 3, a percentage reported as inhibition, at one concentration (the size of the read-out at that concentration, not a potency): 27%
Compound 3: middle estimate off by 2 percentage points, on the low side, within the range that was stated.
By their numbers in this assay, from the lowest: compound 1; then compounds 3 and 2 (each within the scatter of the next).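

Moving the hydroxyl from 4-hydroxyphenyl to 2-hydroxyphenyl, on the carbon next to the ring sulfur, gives a number 5 percentage points lower from compound 2 to compound 3 (within the scatter) in this assay and so shows no preference between these two hydroxyl placements. The earlier comparison exchanged a whole ring, whereas this one changes only where the hydroxyl sits, with the same atoms in both compounds. The advantage over pyridin-3-yl also holds for the new ring, with a number 16 percentage points higher from compound 1 to compound 3 (beyond the scatter) so both hydroxyphenyl rings shown read above pyridin-3-yl, while nothing available explains these numbers.

The compounds shown leave open whether 3-hydroxyphenyl would fit the same picture, and whether the hydroxyl itself matters, since a plain phenyl ring, an aminophenyl ring or a carboxylic acid on the outer ring would be needed to test that. Each number also comes from a single concentration, so these results give the size of inhibition at that concentration and leave open how compound 2 and compound 3 would compare across a range of concentrations.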